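Lengthening the ether chain on a shared core

The source may report more compounds than this note shows. Statements on the series, on what has been measured and on what is new or still open speak of the compounds shown alone.

Compound 2 `COCNc1n[n+]([O-])c2ccccc2[n+]1[O-]` is tested in a functional assay on K562 cells (Homo sapiens) for cytotoxicity, read by MTT assay, with a stated time of 72 h (a higher number here means a weaker inhibitor, a lower number a stronger inhibitor), where compound 2 gives 3790 nM. Among the three compounds measured, compound 2 stands second highest. Within the data shown here, compound 1 `[O-][n+]1nc(NCOC2CCCCC2)[n+]([O-])c2ccccc21` gives 4880 nM, and the one step bearing on the change examined here is a 1.3-fold lower number from compound 1 to compound 2 (0.11 log units; within the scatter), which stayed within the scatter. Among the measured compounds shown here, compound 3 `COc1ccc2c(c1)[n+]([O-])nc(NCOCc1ccccc1)[n+]2[O-]` gives 240 nM; it differs from compound 2 in two places, so its number alone shows only that a far lower value is reachable. Compound 4 `CCCCCOCNc1n[n+]([O-])c2ccccc2[n+]1[O-]` carries butyl in place of hydrogen on a saturated chain carbon bound to an oxygen on a saturated carbon. Because a 1.3-fold lower number from compound 1 to compound 2 (0.11 log units; within the scatter) lay within the scatter, the expected step here is a 1.1-fold lower number from compound 2 to compound 4 (0.03 log units; within the scatter), no change beyond the scatter. Compound 4 is therefore expected at 3500 nM, with a range from 1500 nM to 8000 nM.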

Compound 4, half-maximal inhibitory concentration: 3300 nM
Estimate against measurement, compound 4: 1.1-fold (0.03 log units) above; measured number inside the range.
By their numbers in this assay, from the lowest: compound 3; then compounds 4, 2 and 1 (each within the scatter of the next).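

With this assay as the read-out, butyl in place of hydrogen (a 1.1-fold lower number from compound 2 to compound 4 (0.06 log units; within the scatter)) and pentyl in place of cyclohexyl (a 1.5-fold lower number from compound 1 to compound 4 (0.17 log units; within the scatter)) both stay within the scatter. Methyl, pentyl and cyclohexyl on this ether oxygen therefore give numbers that cannot be told apart, so a straight chain as long as pentyl adds no measurable change. Nothing measured here explains this flat result. Going by these compounds, whether an amine or a carboxylic acid on this chain would move the number remains open. Compound 3 (240 nM) differs from compound 2 in two places, so which change matters there is also unresolved.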